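Swapping a chlorophenyl for an ethylphenyl: solubility outlook

This account rests on a few compounds, and the source may have more. Where it says the series, first, only, none or still open, it means among the compounds named here.

Measured so far:
compound 1 `Cc1oc(-c2ccc(Cl)cc2)nc1CN1CCC(C(=O)NCCCN2C[C@H](C)C[C@H](C)C2)CC1`: > 72 ug/mL
compound 2 `Cc1ccccc1-c1nc(CN2CCC(C(=O)NCCN3C[C@H](C)C[C@H](C)C3)CC2)c(C)o1`: > 67 ug/mL

Of the compounds shown here, two sharing one core have been tested in a physicochemical assay for solubility, in phosphate buffer, measured as kinetic solubility, at pH 7.4; a lower number here means a less soluble compound, a higher number a more soluble compound. Compound 1 gives > 72 ug/mL, which is a limit of the assay rather than a measured number. Compound 2 gives > 67 ug/mL, also a limit. For the measured compounds named here, compound 1 therefore stands at the top of what the assay reports, and the only other value shown is a limit as well, one sitting at the limit of > 67 ug/mL in this assay, at which 1 of the 2 values shown sits, and one at the limit of > 72 ug/mL in this assay, at which 1 of the 2 values shown sits.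

Compound 3 `CCc1ccccc1-c1nc(CN2CCC(C(=O)NCCCN3C[C@H](C)C[C@H](C)C3)CC2)c(C)o1` has not yet been measured. It differs from compound 1 by 2-ethylphenyl in place of 4-chlorophenyl on an aromatic carbon. Going by the values given here, no step between measured compounds is available, so there is no precedent here for the size of such a change. The expectation is that compound 3 remains near the limit, with a step of an at least 1.0-fold lower number from compound 1 to compound 3 (0.01 log units; that floor lies within the scatter) no larger than the usual scatter. Compound 3 is estimated at 70 ug/mL, within a range from 30 ug/mL to 150 ug/mL.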

Compound 3, solubility: 55.9 ug/mL
Compound 3: the middle estimate sits 1.3-fold (0.10 log units) above what was measured; the measured number falls inside the stated range.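

Compound 3 is the only compound shown with an exact number in this assay, at 55.9 ug/mL, so this series now has one firm reading to set later results against. Putting 2-ethylphenyl in place of 4-chlorophenyl on the aromatic carbon gives an at least 1.2-fold lower number from compound 1 to compound 3 (0.10 log units; that floor lies within the scatter), so the smallest step the data allow does not go beyond the usual scatter. The real size of the step remains unknown because compound 1 has only a limit and no exact number: the limit of > 72 ug/mL in this assay, at which 1 of the 3 values shown sits.

This single swap changes both the substituent on the phenyl ring and its place on that ring, so neither can be judged alone. On these data alone, how an unsubstituted phenyl, or a phenyl carrying a methoxy group or an amine, would read in this assay remains open.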